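The source may hold more compounds than are shown below. What is called first, only, known or untested is meant among the compounds shown, and "the series" means these compounds.

Measured so far in a functional assay on ASPC1 cells (Homo sapiens) for cytotoxicity; on this read-out higher numbers stand for weaker inhibition and lower numbers for stronger inhibition:

- Compound 1 `COc1ccc2nc(NC(=O)CCCCC(=O)NO)sc2c1`: 23.9 ug/mL
- Compound 2 `CS(=O)(=O)c1ccc2nc(NC(=O)CCCCCCC(=O)NO)sc2c1`: 13.5 ug/mL
- Compound 3 `O=C(CCCCC(=O)Nc1nc2ccc([N+](=O)[O-])cc2s1)NO`: > 30 ug/mL

The entry for compound 3 is a limit of the assay and not a number. That leaves two true numbers to compare. Compound 2 gives 13.5 ug/mL, compound 1 gives 23.9 ug/mL, and these two values lie within the scatter of each other.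

Compound 4 `CCOc1ccc2nc(NC(=O)CCCCCCC(=O)NO)sc2c1` has not yet been measured. It differs from compound 2 at one place ethoxy in place of methylsulfonyl on an aromatic carbon.

Among the compounds with values here, only one measured step swaps a single group on an aromatic carbon. That step is an at least 1.2-fold higher number from compound 1 to compound 3 (0.09 log units; that floor lies within the scatter), and it ends at a limit (the limit of > 30 ug/mL in this assay, at which 1 of the 3 values shown sits). Going by these compounds, its true size therefore stays open, and its floor gives no firm guide. Neither methylsulfonyl nor ethoxy takes part in it. No step beyond the scatter is therefore expected in this assay, and neither direction is favoured.

The expected step is a 1.0-fold lower number from compound 2 to compound 4 (0.02 log units; within the scatter). For compound 4 the estimated value is 13 ug/mL, with an expected range from 6 ug/mL to 28 ug/mL.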

Compound 4, half-maximal inhibitory concentration: 9.88 ug/mL
Beside the measured number, compound 4's estimate is 1.3-fold (0.12 log units) above it; the measured number falls inside the stated range.
By their numbers in this assay, from the lowest: compounds 4, 2 and 1 (each within the scatter of the next, the first and the last beyond it). At a limit, above all of these: compound 3.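

Ethoxy in place of methylsulfonyl on an aromatic carbon gives a 1.4-fold lower number from compound 2 to compound 4 (0.14 log units; within the scatter) in this assay, and this is the first single-group swap on an aromatic carbon in these compounds that can be read as a real number at both ends. The two groups differ in their heavy atoms and in their hydrogen-bond acceptors, yet compound 2 and compound 4 cannot be told apart in this read-out, so this position accepts this particular exchange without a step beyond the scatter. Nothing measured here gives a reason for this result.

Compound 3 gives a limit and not a number, so the step that ends at it cannot be read and shows nothing firm about nitro on an aromatic carbon. Within the data shown here, whether an amine or a carboxylic acid on this aromatic carbon, or a longer chain in place of the one carried by compound 2 and compound 4, would also stay within the scatter remains open.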